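The source may hold more compounds than are shown below. What is called first, only, known or untested is meant among the compounds shown, and "the series" means these compounds.

Measured compounds:

Compound 1, `CCCCCCCCNC(=N)NC(=N)Nc1ccccc1`: 4.43
Compound 2, `CCCCCCNC(=N)NC(=N)Nc1ccc(C(F)(F)F)cc1`: 4.31
Compound 3, `CCCCCCCCCCNC(=N)NC(=N)Nc1ccccc1`: 5.43

All three values come from a physicochemical assay for lipophilicity, in phosphate buffer, measured as octanol-water partition, at pH 11.5; a higher number here means a more lipophilic compound, a lower number a more polar compound. Compound 3 differs from compound 1 by ethyl in place of hydrogen on a saturated chain carbon, eight bonds along the chain from an amine nitrogen, and this change made a step of a number 1.00 log units higher from compound 1 to compound 3 (beyond the scatter). Compound 2 and compound 1 differ in more than one place, so the difference between the two cores is not broken down here; what their values show is that compound 1 gives 4.43 and compound 2 gives 4.31, a gap that lies within the usual scatter.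

Compound 4, `CCCCCCCCNC(=N)NC(=N)Nc1ccc(C(F)(F)F)cc1`, has not yet been measured. It differs from compound 2 by ethyl in place of hydrogen on a saturated chain carbon, six bonds along the chain from an amine nitrogen. Within the data shown here, this is the same kind of change as the one from compound 1 to compound 3, though the place is not identical: there it sat eight bonds along the chain from an amine nitrogen, here six bonds along the chain from an amine nitrogen. Because compound 1 to compound 3 gave a number 1.00 log units higher from compound 1 to compound 3 (beyond the scatter), a step of about a number 1.00 log units higher from compound 2 to compound 4 (beyond the scatter) is expected from compound 2 to compound 4 in this assay. For compound 4 the value is therefore estimated at 5.31, with a likely range from 5 to 5.6.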

Compound 4, partition coefficient: 5.31
Beside the measured number, compound 4's estimate shows no gap at the digits printed; low and high end bracket the measured number.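

In this assay, ethyl in place of hydrogen on a saturated chain carbon gave a number 1.00 log units higher from compound 2 to compound 4 (beyond the scatter), the same size as a number 1.00 log units higher from compound 1 to compound 3 (beyond the scatter), so this change carried from the core of compound 1 to the core of compound 2 with its size intact. Among these compounds, that is only one pair of cores, with the change six bonds along the chain from an amine nitrogen in one and eight bonds along it in the other, so it does not show that the step would hold on another core or at another place on the chain. Trifluoromethyl in place of hydrogen on an aromatic carbon gave a number 0.88 log units higher from compound 1 to compound 4 (beyond the scatter), a single reading with no second pair to check it against, and nothing offered here explains either step.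

As far as these compounds go, whether the ethyl step keeps its size on a longer chain remains open. So does what happens when an amine or a carboxylic acid stands on that aromatic carbon instead of trifluoromethyl.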